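Swapping the chloroacetamide for a dichloropyridine amide

The compounds below may be only part of what the source reports. "The series", "measured", "known", "first", "only" and "open" are said of these compounds alone.

Measured compounds:
- compound 1, `C=CC(=O)Nc1cccc(-c2nc3ccccc3s2)c1`: > 25000 nM in an ADME assay on HepG2 cells (Homo sapiens) for inhibition, with a stated time of 72 h; on this read-out lower numbers stand for an effect already at smaller amounts and higher numbers for an effect only at larger amounts of compound
- compound 2, `C=C(C)C(=O)Nc1cccc(-c2nc3ccccc3s2)c1`: > 25000 nM in this assay
- compound 3, `O=C(CCl)Nc1cccc(-c2nc3ccccc3s2)c1`: 16000 nM in this assay

The value given for compound 1 in this assay is a limit of the assay, not a number. The same holds for compound 2, whose value in this assay is also a limit. For the measured compounds named here, compound 3 therefore stands as the only compound of the three with a measured number; the other two sit at the limit of > 25000 nM in this assay, at which 2 of the 3 values shown sit. Against those limits, the change from vinyl to chloromethyl on the carbonyl carbon reads as an at least 1.5-fold lower number from compound 1 to compound 3 (0.19 log units; that floor lies within the scatter), and from 1-methylethenyl as an at least 1.5-fold lower number from compound 2 to compound 3 (0.19 log units; that floor lies within the scatter); the methyl step that the two limits leave unreadable from compound 1 to compound 2 cannot be read at all.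

Compound 4, `O=C(Nc1cccc(-c2nc3ccccc3s2)c1)c1ccc(Cl)nc1Cl`, differs from compound 3 by 2,6-dichloropyridin-3-yl in place of chloromethyl on a carbonyl carbon. Going by the values given here, none of the measured steps touches a change of this kind: each of them alters only a small chain on the carbonyl carbon, and two of them are bounded by limits. Among the compounds with values here, the steps that can be read are within the scatter, so they give no direction for the step to compound 4, which is expected as a 1.3-fold higher number from compound 3 to compound 4 (0.10 log units; within the scatter) in this assay. Compound 4 is thus estimated at 20000 nM, with a range from 5000 nM to 60000 nM, and a real chance that only a limit is reported.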

Compound 4, half-maximal effective concentration: > 25000 nM
Compound 4: no number, only a limit (the forecaster's own chance of this, stated with the estimate: 50%); middle value at least 1.2-fold (0.09 log units) from the limit.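

Compound 4 also gives only a limit of the assay, not a number, in this assay, so a six-membered aromatic ring on the carbonyl carbon, here 2,6-dichloropyridin-3-yl, leads to the same limit as the vinyl and 1-methylethenyl groups, a limit now shared by most of the series: the limit of > 25000 nM in this assay, at which 3 of the 4 values shown sit. The one step that can be read is an at least 1.5-fold higher number from compound 3 to compound 4 (0.19 log units; that floor lies within the scatter), so it shows no firm difference between chloromethyl and 2,6-dichloropyridin-3-yl at this place, although chloromethyl remains the only group shown here that gives a measured number. The steps to compound 4 from compound 1 and from compound 2 join two limits and cannot be read.

As far as these compounds go, how far the true values of compound 1, compound 2 and compound 4 lie from their shared limit stays open, and so does the size of any gap between them and compound 3. Also open, from the compounds shown here alone, is whether an amine, a carboxylic acid or a longer chain on the carbonyl carbon would give a number in this assay at all.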